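A few compounds are considered here, and "the series" means these few. Any claim that something is new, unique, unknown or untested is made for them only; others in the source may bear on it.

Measured so far in a functional assay on HL-60 cells (Homo sapiens) for antiproliferative activity, with a stated time of 72 h; on this read-out higher numbers stand for weaker inhibition and lower numbers for stronger inhibition:
compound 1 `OC[C@H]1O[C@@H](n2cnc3c(NCc4ccccc4Cl)ncnc32)[C@H](O)[C@@H]1O` gives 1600 nM
compound 2 `OC[C@H]1O[C@@H](n2cnc3c(NCc4cccc(Br)c4)ncnc32)[C@H](O)[C@@H]1O` gives 8000 nM
compound 3 `COc1cc(CNc2ncnc3c2ncn3[C@@H]2O[C@H](CO)[C@@H](O)[C@H]2O)cc(OC)c1` gives 20200 nM

Compound 2 holds the second highest number of the three. Its nearest neighbour is compound 3, reached by a 2.5-fold higher number from compound 2 to compound 3 (0.40 log units; beyond the scatter); its furthest is compound 1, from which compound 2 is reached by a 5.0-fold higher number from compound 1 to compound 2 (0.70 log units; beyond the scatter).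

Compound 4 `OC[C@H]1O[C@@H](n2cnc3c(NCc4ccc(F)c(F)c4F)ncnc32)[C@H](O)[C@@H]1O` is not yet measured. It differs from compound 2 in one place: 2,3,4-trifluorophenyl in place of 3-bromophenyl on a saturated chain carbon bound to a nitrogen on an aromatic ring.

Going by the values given here, two measured steps bear on this change, both at the same place on the shared core. Going from the 2-chlorophenyl of compound 1 to the 3-bromophenyl of compound 2 gave a modest rise, a 5.0-fold higher number from compound 1 to compound 2 (0.70 log units; beyond the scatter), and going on to the 3,5-dimethoxyphenyl of compound 3 gave a further modest rise, a 2.5-fold higher number from compound 2 to compound 3 (0.40 log units; beyond the scatter). Within this small set the two halogen-bearing phenyl groups give lower numbers than the dimethoxy-bearing one, with the 2-chlorophenyl of compound 1 lowest. Replacing one halogen-bearing phenyl with another is therefore expected to move the number by no more than a modest step, most likely keeping compound 4 between compound 1 and compound 3. Compound 4 is expected to give 3000 nM, within 1000 nM to 9000 nM. The expected step from compound 2 is a 2.7-fold lower number from compound 2 to compound 4 (0.43 log units; beyond the scatter), a lowering that could still fall inside the scatter.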

Compound 4, half-maximal inhibitory concentration: 13000 nM
Estimate against measurement, compound 4: 4.3-fold (0.64 log units) below, outside the stated range (above it).
By their numbers in this assay, from the lowest: compound 1; then compounds 2, 4 and 3 (each within the scatter of the next, the first and the last beyond it).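

In this assay, a halogen on the phenyl group does not by itself keep the number low at this place, on a saturated chain carbon bound to a nitrogen on an aromatic ring: there is an 8.1-fold higher number from compound 1 to compound 4 (0.91 log units; beyond the scatter) and so a step beyond the scatter, whereas a 1.6-fold higher number from compound 2 to compound 4 (0.21 log units; within the scatter) and a 1.6-fold lower number from compound 3 to compound 4 (0.19 log units; within the scatter) are both within it. The 2,3,4-trifluorophenyl group of compound 4 therefore cannot be told apart from the 3-bromophenyl group of compound 2 or the 3,5-dimethoxyphenyl group of compound 3, although compound 2 and compound 3 are separated beyond the scatter. Compound 1 alone now stands apart as the most potent of the four, with compound 2 and compound 4 going against any reading of halogen-bearing phenyl groups as a low-number class, and nothing measured here accounts for this.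

With a single chlorine-bearing compound, the compounds shown leave open whether the lower number of compound 1 follows the chlorine itself or its place on the ring, which a 3-chlorophenyl or 2-bromophenyl group would test. Also open, as far as these compounds go, is how this position takes a phenyl group carrying an amine or a carboxylic acid, or a longer chain in place of the saturated chain carbon.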